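Cyclopentylmethyl Replaces a Carboxylic Acid on the Shared Core

The compounds below may be only part of what the source reports. "The series", "measured", "known", "first", "only" and "open" are said of these compounds alone.

Measured compounds:
compound 1, `CCCn1c(=O)c2nc(C3CCC(C(=O)OC)CC3)[nH]c2n(CCC)c1=O`: 130 nM
compound 2, `CCCn1c(=O)c2nc(C3CCC(C(=O)N(C)CCN(C)C)CC3)[nH]c2n(CCC)c1=O`: 17 nM; 85 nM (2 entries)
compound 3, `CCCn1c(=O)c2nc(C3=C(C(=O)O)CCC3)[nH]c2n(CCC)c1=O`: > 10000 nM

In a functional assay for antagonist activity at adenosine receptor A1 (Homo sapiens) (a higher number here means a weaker inhibitor, a lower number a stronger inhibitor), compound 3 is reported only as a limit, > 10000 nM, and a further entry gives no single number either. Compound 3 therefore stands apart from compound 1, which gives 130 nM in this assay, and from compound 2, whose several entries are recorded as the several entries of compound 2 in this assay, 17 nM; 85 nM (2 entries). The limit is noted as the limit of > 10000 nM in this assay, at which 1 of the 3 values shown sits.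

Compound 4, `CCCn1c(=O)c2nc(CC3CCCC3)[nH]c2n(CCC)c1=O`, has not yet been measured. The change from compound 3 is cyclopentylmethyl in place of 2-carboxycyclopent-1-en-1-yl on an aromatic carbon. Among the measured compounds shown here, no measured pair covers this change, so the expectation rests on the values of compound 1 and compound 2, both of which carry a saturated six-membered ring on the same aromatic carbon and reach nanomolar range.

Compound 4 is expected to reach 30 nM in this assay, with a range from 5 nM to 300 nM. The expected step is large and toward stronger inhibition, estimated as an at least 330-fold lower number from compound 3 to compound 4 (2.52 log units; beyond the scatter).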

Compound 4, inhibition constant: 69 nM
Compound 4: middle estimate off by 2.3-fold (0.36 log units), on the low side; the measured number falls inside the stated range.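

In this assay, among the compounds shown here, cyclopentylmethyl in place of 2-carboxycyclopent-1-en-1-yl gives an at least 140-fold lower number from compound 3 to compound 4 (2.16 log units; beyond the scatter), a comparison in one place that the earlier compounds did not offer, and it shows that this position, on an aromatic carbon between two ring nitrogen atoms, can carry a group without a carboxylic acid and still give a nanomolar value. The size of this step is only a lower bound, as compound 3 is recorded as a limit and not as a number: the limit of > 10000 nM in this assay, at which 1 of the 4 values shown sits. The whole group changes at once, so this pair does not separate the loss of the carboxylic acid from the other differences between the two groups.

Left open is whether the carboxylic acid alone decides the result, which a cyclopentylmethyl group carrying a carboxylic acid on its ring would address. Also open, going by these compounds, is how an amine on that ring would compare with compound 4.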